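The compounds below may be only part of what the source reports. "The series", "measured", "known", "first", "only" and "open" are said of these compounds alone.

Measured in an assay on isolated protein for binding affinity to corticotropin-releasing factor receptor 1 (Homo sapiens); on this read-out lower numbers stand for stronger inhibition and higher numbers for weaker inhibition:
compound 1 `CC(=O)/C(=N\Nc1ccccc1)N(C)c1cccc(Cl)c1`, a limit of the assay: > 10000 nM
compound 2 `CC(=O)/C(=N\Nc1ccccc1C(F)(F)F)N(C)c1cccc(Cl)c1`, a limit of the assay: > 10000 nM
compound 3 `CC(=O)/C(=N\c1ccc(Cl)cc1)NNc1ccccc1C(F)(F)F`, a limit of the assay: > 10000 nM

All three readings in this assay are limits, not numbers. From compound 2 to compound 1 the change is hydrogen in place of trifluoromethyl on an aromatic carbon. The step it made is a step that the two limits leave unreadable from compound 2 to compound 1, because both readings sit at the limit of > 10000 nM in this assay, at which 3 of the 3 values shown sit. How the core of compound 3 differs from the core of compound 2 is not broken down here; both give only a limit.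

Compound 4 `CC(=O)/C(=N\c1ccc(Cl)cc1)NNc1ccccc1` is not yet measured. It differs from compound 3 by hydrogen in place of trifluoromethyl on an aromatic carbon, the same change as from compound 2 to compound 1, described at the same kind of place in the same words. The earlier change gave no readable size, so the step from compound 3 to compound 4 is expected to be a step that the limit leaves unreadable from compound 3 to compound 4. This expectation rests on compound 3, whose reading is only a limit, and on the unreadable earlier step. Compound 4 is expected near 20000 nM, between 5000 nM and 100000 nM, most likely reported again as a limit.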

Compound 4, inhibition constant: > 10000 nM
Compound 4: a limit, no number (the forecaster's own chance of this, stated with the estimate: 85%); the middle value does not contradict the limit.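

No step can be read from compound 3 to compound 4 in this assay because both readings are limits and not numbers: (the limit of > 10000 nM in this assay, at which 4 of the 4 values shown sit). The compounds shown leave open whether hydrogen in place of trifluoromethyl on an aromatic carbon changes the affinity at all, and what any of these four compounds would give as an actual number.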